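Shortening the Alkyl Chain from Octyl to Pentyl

The compounds below may be only part of what the source reports. "The series", "measured", "known", "first", "only" and "open" are said of these compounds alone.

Compounds measured in an ADME assay on HEK293 cells (Homo sapiens) for cytotoxicity, read by sulforhodamine B assay, with a stated time of 48 h, tested at 10 uM; a lower number here means less inhibition, a higher number more inhibition at the concentration tested (going by the name of the read-out):
Compound 1, `CCCCCCCc1cn(C(c2ccccc2)c2cc3cc(Br)ccc3nc2OC)nn1`, gives 0.17%.
Compound 2, `CCCCCCc1cn(C(c2ccccc2)c2cc3cc(Br)ccc3nc2OC)nn1`, gives -3.17%.
Compound 3, `CCCCCCCCc1cn(C(c2ccccc2)c2cc3cc(Br)ccc3nc2OC)nn1`, gives 14.6%.

Compound 3 stands highest of the three, and both steps leading to it lie beyond the scatter: a number 14.4 percentage points higher from compound 1 to compound 3 (beyond the scatter) and a number 17.8 percentage points higher from compound 2 to compound 3 (beyond the scatter). Compound 4, `CCCCCc1cn(C(c2ccccc2)c2cc3cc(Br)ccc3nc2OC)nn1`, is not yet measured. It differs from compound 3 in one place: hydrogen in place of propyl on a saturated chain carbon, five bonds along the chain from an aromatic carbon. The relevant comparisons are the chain-length steps already seen. Taking one chain carbon away between compound 1 and compound 2 gave a number 3.3 percentage points lower from compound 1 to compound 2 (within the scatter), a change within the scatter, whereas adding carbons up to compound 3 raised the number modestly. Cutting three carbons from compound 3 should therefore at least undo that rise and bring the number back toward the near-zero values of compound 1 and compound 2. The step is expected to be a number 16.6 percentage points lower from compound 3 to compound 4 (beyond the scatter), a drop beyond the scatter. Compound 4 is expected to give -2% in this assay, within a range from -13% to 9%.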

Compound 4, a percentage reported as inhibition, at one concentration (the size of the read-out at that concentration, not a potency): -2%
Compound 4: the middle estimate sits on the measured number at the digits printed; the measured number falls inside the stated range.
By their numbers in this assay, from the lowest: compounds 2, 4 and 1 (each within the scatter of the next); then compound 3.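

In this assay, the pentyl chain of compound 4 cannot be told apart from the two next longer chains, with a number 1.2 percentage points higher from compound 2 to compound 4 (within the scatter) and a number 2.2 percentage points lower from compound 1 to compound 4 (within the scatter). The octyl chain of compound 3 alone stands apart from it, at a number 16.6 percentage points lower from compound 3 to compound 4 (beyond the scatter), so the shorter chains now form a level stretch and the rise appears only at octyl. Going from pentyl to hexyl and going from heptyl to octyl are the same kind of change on the chain, yet they do not give the same step: the same change on two cores in this assay, a number 14.4 percentage points higher (beyond the scatter) from compound 1 to compound 3 and a number 1.2 percentage points lower (within the scatter) from compound 4 to compound 2, 15.6 percentage points apart, beyond the scatter of two such steps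

The compounds shown leave open whether a longer chain, such as decyl, would raise the number further, and whether a much shorter one, such as ethyl, would stay on the level stretch. They also leave open how a chain carrying an amine or a carboxylic acid would read.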